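Vinyl in place of iodo on two related cores

The source may report more compounds than this note shows. Statements on the series, on what has been measured and on what is new or still open speak of the compounds shown alone.

Four compounds are compared in a functional assay on NCI-H522 cells (Homo sapiens) for cytotoxicity, with a stated time of 3 days; on this read-out lower numbers stand for stronger inhibition and higher numbers for weaker inhibition. Compound 2 `Ic1nc2ccccc2s1` gives in this assay only a limit, > 40000 nM. Compound 1 `C=Cc1nc2ccccc2s1` likewise gives only a limit in this assay, > 40000 nM. The change between them is vinyl in place of iodo on an aromatic carbon; the resulting step, a step that the two limits leave unreadable from compound 2 to compound 1, cannot be read because of the limit of > 40000 nM in this assay, at which 2 of the 3 values shown sit.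

Among the measured compounds shown here, compound 3 `Ic1nc2ccccc2o1` gives in this assay 11700 nM, the only number among the three measured compounds. How the core of compound 3 differs from the core of compound 2 is not broken down here.

Compound 4 `C=Cc1nc2ccccc2o1` has not been measured. It differs from compound 3 by vinyl in place of iodo on an aromatic carbon. This is the same kind of change as that from compound 2 to compound 1, not the same change: in compound 2 and compound 1 the carbon sits on a five-membered aromatic ring with 1 nitrogen and 1 sulfur, whereas in compound 3 and compound 4 it sits on a five-membered aromatic ring with 1 nitrogen and 1 oxygen.

Since the step from compound 2 to compound 1 is unreadable between two limits, it gives no direction for the size of the step from compound 3 to compound 4; the expected step is therefore set near zero, a 1.3-fold higher number from compound 3 to compound 4 (0.11 log units; within the scatter), with wide uncertainty. Compound 4 is estimated to give in this assay about 15000 nM, expected between 4000 nM and 60000 nM.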

Compound 4, half-maximal inhibitory concentration: > 40000 nM
Compound 4: a limit, no number; the forecaster's own chance of this, stated with the estimate: 35%; middle value at least 2.6-fold (0.42 log units) away from the limit.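

In this assay, among the compounds shown here, the one readable step for vinyl in place of iodo on an aromatic carbon is an at least 3.4-fold higher number from compound 3 to compound 4 (0.53 log units; beyond the scatter), so on the core of compound 3 this change goes with weaker inhibition, beyond the scatter. For the compounds shown here, the same change on the core of compound 2 cannot be read, as compound 2 and compound 1 both give only limits, so the series shows no second step to set beside this one and does not show that the change carries in the same direction or size from one core to the other. Compound 4 also gives a limit and no number, so the step is only a lower bound and its full size cannot be read, because most of the values here are limits: the limit of > 40000 nM in this assay, at which 3 of the 4 values shown sit.

At this carbon the compounds shown hold only iodo and vinyl, and in this assay compound 3 with 11700 nM is the sole number, so it remains open whether any other group keeps or improves on that value. An amine, a carboxylic acid or a longer chain at that carbon, on either core, could give numbers in place of limits and allow a real comparison between the cores.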